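Swapping the aryl group on the triazole nitrogen

The compounds below may be only part of what the source reports. "The series", "measured", "known", "first", "only" and "open" are said of these compounds alone.

Measured compounds and their values:
Compound 1 `COc1cc2c(Oc3ccc(NC(=O)c4nnn(-c5ccc(F)c(F)c5)c4C(F)(F)F)cc3F)ccnc2cc1OCCCN1CCC(C)CC1` gives 230 nM in a functional assay on NCI-H460 cells (Homo sapiens) for cytotoxicity, read by MTT assay, with a stated time of 72 h; a lower number here means a stronger inhibitor, a higher number a weaker inhibitor.
Compound 2 `COc1cc2c(Oc3ccc(NC(=O)c4nnn(-c5ccccc5Cl)c4C(F)(F)F)cc3F)ccnc2cc1OCCCN1CCN(C)CC1` gives 330 nM in this assay.
Compound 3 `COc1cc2c(Oc3ccc(NC(=O)c4nnn(-c5ccc(C)cc5)c4C(F)(F)F)cc3F)ccnc2cc1OCCCN1CCN(C)CC1` gives 1240 nM in this assay.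

Among the compounds with values here, compound 3 has the highest number of the three, and in the one single-point step on record the value rose a 3.8-fold higher number from compound 2 to compound 3 (0.57 log units; beyond the scatter). Compound 4 `COc1cc2c(Oc3ccc(NC(=O)c4nnn(-c5ccc(F)c(F)c5)c4C(F)(F)F)cc3F)ccnc2cc1OCCCN1CCN(C)CC1` returns to the aryl group that compound 1 carries: 3,4-difluorophenyl in place of 4-methylphenyl on an aromatic nitrogen. Within the data shown here, no step that differs only at this aryl group connects compound 4 to a measured compound; compound 1 differs from it in the basic amine as well, and compound 2 carries a different aryl group. What the two values show is that compound 1, with the same difluorophenyl, sits well below compound 3, and that compound 2, which shares the amine of compound 4, also sits below compound 3. A step down beyond the scatter is therefore expected, a 4.4-fold lower number from compound 3 to compound 4 (0.65 log units; beyond the scatter). Compound 4 is estimated at 280 nM, in the range 120 nM to 650 nM.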

Compound 4, half-maximal inhibitory concentration: 230 nM
Compound 4: the middle estimate sits 1.2-fold (0.09 log units) above what was measured, and the stated range covers the measured number.
By their numbers in this assay, from the lowest: compounds 1, 4 and 2 (each within the scatter of the next); then compound 3.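

With the 4-methylpiperazin-1-yl amine held fixed in this assay, the move to 3,4-difluorophenyl brings a 5.4-fold lower number from compound 3 to compound 4 (0.73 log units; beyond the scatter) and so sets 4-methylphenyl apart from it, while a 1.4-fold lower number from compound 2 to compound 4 (0.16 log units; within the scatter) does not separate 3,4-difluorophenyl from 2-chlorophenyl. The first direct test of the amine gives no change at the digits printed from compound 1 to compound 4 (within the scatter) when 4-methylpiperazin-1-yl replaces 4-methylpiperidin-1-yl, so in this pair, with 3,4-difluorophenyl on the aromatic nitrogen, the two amines are not told apart. No measurement offered here accounts for either result.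

On these data alone, it remains open whether the two amines would also match with 4-methylphenyl or 2-chlorophenyl on the aromatic nitrogen. Also open, as far as these compounds go, is where an unsubstituted phenyl or a 4-chlorophenyl would fall, and with it whether the methyl group itself goes with the higher number.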